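The compounds below may be only part of what the source reports. "The series", "measured", "known", "first", "only" and "open" are said of these compounds alone.

Series notes. Compound 1 `O=C(CCCCCCc1ccccc1)c1ncc(-c2cccc(O)c2)o1` and compound 2 `O=C(CCCCCCc1ccccc1)c1ncc(-c2ccc(C(=O)C(F)(F)F)cc2)o1` share the same core and differ only in the aryl group on it. In an assay (Rattus norvegicus) for inhibition of Fatty-acid amide hydrolase 1 (Homo sapiens) (a higher number here means a weaker inhibitor, a lower number a stronger inhibitor), compound 1 gives 50 nM. In this assay compound 2 gives 65 nM. The two numbers lie within the usual scatter of each other, so no order between compound 1 and compound 2 can be read from them.

Compound 3 `N#Cc1ccc(-c2cnc(C(=O)CCCCCCc3ccccc3)o2)cc1` is not yet measured. Against compound 1 the difference is 4-cyanophenyl in place of 3-hydroxyphenyl on an aromatic carbon. Within the data shown here, no measured step of this kind exists, and compound 2 gives a second aryl group with a number in the same region as compound 1. On that basis no step beyond the scatter is expected from compound 1 to compound 3; the expected step of a 1.2-fold higher number from compound 1 to compound 3 (0.08 log units; within the scatter) is small. For compound 3 the estimate in this assay is 60 nM, within a range of 20 nM to 200 nM.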

Compound 3, inhibition constant: 40 nM
Compound 3: middle estimate off by 1.5-fold (0.18 log units), on the high side, within the range that was stated.
By their numbers in this assay, from the lowest: compounds 3, 1 and 2 (each within the scatter of the next).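

In this assay, the aryl group on this aromatic carbon can change from 3-hydroxyphenyl to 4-cyanophenyl, which carries no hydrogen-bond donor, with only a 1.3-fold lower number from compound 1 to compound 3 (0.10 log units; within the scatter). Cyano in place of (trifluoromethyl)carbonyl gives a 1.6-fold lower number from compound 2 to compound 3 (0.21 log units; within the scatter), so all three aryl groups now sit within the scatter, and neither the hydroxyl nor the (trifluoromethyl)carbonyl group shows a measurable advantage over cyano here. No measurement in hand bears on why these aryl groups give such similar numbers.

Still open, from the compounds shown here alone, is whether any aryl group at this position moves the number beyond the scatter, for example one carrying a carboxylic acid or an amine. Because compound 1 and compound 3 differ in both the substituent and its place on the ring, the contribution of each remains unresolved.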